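The compounds below may be only part of what the source reports. "The series", "measured", "known", "first", "only" and "open" are said of these compounds alone.

Compound 1 `CCCC/C=C\CCCCCCCCCc1cc(=O)c2c(O)cc(OCOC)cc2o1` carries a long unsaturated chain on its core, along with a hydroxy group and a methoxymethoxy group. In a functional assay on MCF7 cells (Homo sapiens) for antiproliferative activity, read by MTT assay (on this read-out higher numbers stand for weaker inhibition and lower numbers for stronger inhibition), compound 1 gives > 67200 nM, and this is a limit of the assay, not a number. Among the compounds with values here, the only other measured compound is compound 2 `CC/C=C\C/C=C\C/C=C\CCCCCCCc1cc(=O)c2c(O)cc(O)cc2o1`, which gives 17500 nM in this assay. Within the data shown here, it differs from compound 1 in more than one place, and no pair of measured compounds differs in just one, so the data offer no direct guide to a single small change.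

Compound 3 `CCCC/C=C\CCCCCCCCCc1cc(=O)c2c(O)c(C)c(OCOC)cc2o1` is compound 1 with methyl in place of hydrogen on an aromatic carbon, ortho to a hydroxy group and ortho to a methoxymethoxy group (methyl in place of hydrogen on an aromatic carbon). The expectation for this assay is no step beyond the scatter, with neither direction favoured. A limit rather than a number is quite possible for this compound as well. The estimated size of the change is a step that the limit leaves unreadable from compound 1 to compound 3. For compound 3 the expected value is 70000 nM, with a range from 25000 nM to 150000 nM.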

Compound 3, half-maximal inhibitory concentration: > 67200 nM
Compound 3 was reported as a limit; the forecaster's own chance of this, stated with the estimate: 60%; the middle value does not contradict the limit.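

Compound 1 and compound 3 are both reported in this assay only as a limit and not as a number, so no step can be read for the added methyl: the limit of > 67200 nM in this assay, at which 2 of the 3 values shown sit. The compounds shown leave open whether methyl in place of hydrogen on this aromatic carbon changes the activity at all, and in which direction.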